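From thiophen-3-yl to furan-2-yl on a carbonyl carbon

The source may hold more compounds than are shown below. What is called first, only, known or untested is meant among the compounds shown, and "the series" means these compounds.

Among the compounds with values here, in a functional assay on A2780 cells (Homo sapiens) for antiproliferative activity, read by fluorescence, with a stated time of 72 h (on this read-out higher numbers stand for weaker inhibition and lower numbers for stronger inhibition), compound 3 `CN1CCC(C(=O)N2Cc3c(NC(=O)c4ccsc4)n[nH]c3C2(C)C)CC1` gives 140 nM, the lower of the two exact numbers so far. Compound 2 `CN1CCC(C(=O)N2Cc3c(NC(=O)NCc4ccccc4)n[nH]c3C2(C)C)CC1` gives 2680 nM. Compound 1 `CC(=O)N1CCN(C(=O)N2Cc3c(NC(=O)c4ccc(F)cc4)n[nH]c3C2(C)C)CC1` is reported only as a limit of the assay, > 10000 nM.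

Compound 4 `CN1CCC(C(=O)N2Cc3c(NC(=O)c4ccco4)n[nH]c3C2(C)C)CC1` has furan-2-yl in place of thiophen-3-yl on a carbonyl carbon. Within the data shown here, only one measured step bears on this place: a 19-fold lower number from compound 2 to compound 3 (1.28 log units; beyond the scatter), a large step beyond the scatter, in which thiophen-3-yl replaced benzylamino. The new change is different in kind, since one five-membered aromatic ring with 1 hetero atom gives way to another, and furan-2-yl itself has not yet been measured. A step of that size is therefore not expected, and the estimate starts from compound 3 at 140 nM. The expected change is a slightly higher number, a 1.4-fold higher number from compound 3 to compound 4 (0.15 log units; within the scatter), probably within the scatter. For compound 4 the estimated value is 200 nM, with an expected range of 70 nM to 600 nM.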

Compound 4, half-maximal inhibitory concentration: > 5000 nM
Compound 4: only a limit was reported; the forecaster's own chance of this, stated with the estimate: 2%; at least 25-fold (1.39 log units) between middle value and limit.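

The result shows that this place on the carbonyl carbon does not treat all five-membered aromatic rings alike: thiophen-3-yl and furan-2-yl match in every count given, yet in this assay there is an at least 35-fold higher number from compound 3 to compound 4 (1.55 log units; beyond the scatter). The result for compound 4 is a limit, not a number: the limit of > 5000 nM in this assay, at which 1 of the 4 values shown sits. Against benzylamino on the same carbon, the change gives an at least 1.8-fold higher number from compound 2 to compound 4 (0.27 log units; that floor lies within the scatter), so furan-2-yl cannot be firmly placed behind benzylamino.

The change swaps sulfur for oxygen and also moves the ring's point of attachment, and the compounds shown do not separate these two differences. Thiophen-2-yl or furan-3-yl on the same carbonyl carbon would pull them apart, and how far compound 4 lies past its limit remains open.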